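The compounds below may be only part of what the source reports. "The series", "measured", "known", "first", "only" and "open" are said of these compounds alone.

Measured so far in a functional assay on DU-145 cells (Homo sapiens) for cytotoxicity, in the presence of a further agent that is not named here; on this read-out lower numbers stand for stronger inhibition and higher numbers for weaker inhibition:

compound 1 `Clc1ccc(-c2cc(-c3ccsc3)nc(-c3ccccc3Cl)c2)o1` — compound 1 gives 19300 nM
compound 2 `Clc1ccc(-c2cc(-c3cccnc3)nc(-c3cccs3)c2)o1` — compound 2 gives 13000 nM
compound 3 `Cc1ccccc1-c1cc(-c2ccc(Cl)o2)cc(-c2ccsc2)n1` — compound 3 gives 24800 nM

Compound 3 carries the highest of the three numbers, but its neighbours sit close: the gap to compound 1 and the gap to compound 2 both fall within the usual scatter, so no order among the three can be read from these values. Within the data shown here, the one single-point step measured so far, a 1.3-fold higher number from compound 1 to compound 3 (0.11 log units; within the scatter), shows that the methyl in place of chloro on an aromatic carbon leaves the read-out essentially unchanged.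

The next compound, compound 4 `Clc1ccc(-c2cc(-c3cccnc3)nc(-c3ccsc3)c2)o1`, differs from compound 3 in one place: pyridin-3-yl in place of 2-methylphenyl on an aromatic carbon. Among the measured compounds shown here, no measured pair isolates this exchange, so the measured step gives no direct guidance. What can be said is that compound 2, which also bears a pyridin-3-yl group on its core, gives a value within the scatter of compound 3, and compound 1 and compound 3 with their carbon-only six-membered rings do the same. On that basis no step beyond the scatter is expected in this assay for compound 4 in either direction; the expected step is a 1.6-fold lower number from compound 3 to compound 4 (0.19 log units; within the scatter). Compound 4 is therefore estimated at 16000 nM, with a range from 7000 nM to 35000 nM.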

Compound 4, half-maximal inhibitory concentration: 21600 nM
The estimate for compound 4 lay 1.4-fold (0.13 log units) below the measured number; the measured number falls inside the stated range.
By their numbers in this assay, from the lowest: compounds 2, 1, 4 and 3 (each within the scatter of the next).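

In this assay, the aromatic carbon next to the ring nitrogen accepts pyridin-3-yl in place of 2-methylphenyl with a 1.1-fold lower number from compound 3 to compound 4 (0.06 log units; within the scatter) and pyridin-3-yl in place of 2-chlorophenyl with a 1.1-fold higher number from compound 1 to compound 4 (0.05 log units; within the scatter). At this position, therefore, a six-membered aromatic ring with 1 hetero atom and one hydrogen-bond acceptor is not separated by this read-out from either carbon-only ring shown, whether that ring carries methyl or chloro. Among these compounds, the exchange of thiophen-3-yl for thiophen-2-yl, readable here for the first time, gives a 1.7-fold higher number from compound 2 to compound 4 (0.22 log units; within the scatter) and so also stays unresolved, while no independent measurement bears on why these steps remain so small.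

Going by these compounds, with all four compounds inside the scatter of their neighbours, it remains open whether an aminomethyl group, a carboxylic acid or a longer alkyl chain at this position would move the number beyond the scatter. On these data alone, all four also keep the 5-chlorofuran-2-yl group, so the contribution of that group to the read-out stays unknown.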